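Replacing the (4-methylphenyl)sulfonyl ester by hydroxy in compound 4

This account rests on a few compounds, and the source may have more. Where it says the series, first, only, none or still open, it means among the compounds named here.

Notes on a set sharing one core that bears a (4-methylphenyl)sulfonyl ester. Compound 1 `C=C1C[C@]23C[C@@]1(O)CC[C@H]2c1ccc(OS(=O)(=O)c2ccc(C)cc2)c(C)c1[C@@H]3Cn1cc(-c2ccc(Cl)cc2)nn1` carries chloro on an aromatic carbon. In a functional assay on MCF7 cells (Homo sapiens) for cytotoxicity, read by MTT assay, with a stated time of 4 days (a lower number here means a stronger inhibitor, a higher number a weaker inhibitor), compound 1 gives only a limit, > 20000 nM. Compound 2 `C=C1C[C@]23C[C@@]1(O)CC[C@H]2c1ccc(OS(=O)(=O)c2ccc(C)cc2)c(C)c1[C@@H]3Cn1cc(-c2ccc(OC)cc2)nn1` has methoxy in place of that chloro. In this assay compound 2 likewise gives only a limit, > 20000 nM. Compound 3 `C=C1C[C@]23C[C@@]1(O)CC[C@H]2c1ccc(OS(=O)(=O)c2ccc(C)cc2)c(C)c1[C@@H]3Cn1cc(-c2ccc(C)cc2)nn1` has methyl at the same carbon. In this assay compound 3 too gives only a limit, > 20000 nM. All three values sit at one point, (the limit of > 20000 nM in this assay, at which 3 of the 3 values shown sit). Hence the steps among them cannot be read: a step that the two limits leave unreadable from compound 1 to compound 2, a step that the two limits leave unreadable from compound 1 to compound 3 and a step that the two limits leave unreadable from compound 2 to compound 3. Compound 2 thus stands nowhere distinct; it shares the limit with both others.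

Compound 4 `C=C1C[C@]23C[C@@]1(O)CC[C@H]2c1ccc(O)c(C)c1[C@@H]3Cn1cc(-c2ccc(OC)cc2)nn1` differs from compound 2 in one place: hydrogen in place of (4-methylphenyl)sulfonyl on an oxygen on an aromatic ring. Among the compounds with values here, none of the measured steps touches this oxygen; each of them exchanges a group on an aromatic carbon elsewhere. Nothing measured therefore bears on the direction or size of this change, and the starting point of compound 2 is itself only a limit. The expected step of an at least 1.3-fold lower number from compound 2 to compound 4 (0.12 log units; that floor lies within the scatter) is a guess that the value does not move far. Compound 4 is expected in this assay at 15000 nM, within 3000 nM to 60000 nM.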

Compound 4, half-maximal inhibitory concentration: > 20000 nM
Compound 4 was reported as a limit (the forecaster's own chance of this, stated with the estimate: 50%); at least 1.3-fold (0.12 log units) between middle value and limit.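

In this assay compound 4 gives only a limit, > 20000 nM. Compound 2 is also a limit, so the step from compound 2 to compound 4 cannot be read: the limit of > 20000 nM in this assay, at which 4 of the 4 values shown sit.

Open, going by these compounds, is where compound 1, compound 2, compound 3 and compound 4 truly lie past that limit, and so whether hydroxy differs from the (4-methylphenyl)sulfonyl ester at all.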